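This account rests on a few compounds, and the source may have more. Where it says the series, first, only, none or still open, it means among the compounds named here.

Working notes on the series, read in a functional assay on NT2 cells (Homo sapiens) for inhibition; on this read-out higher numbers stand for weaker inhibition and lower numbers for stronger inhibition. Compound 1 (`CCCN(CCC)C(=O)c1cncc(C(=O)N[C@@H](CC(=O)O)C(=O)CSCc2ccc(F)cc2)c1`) reports only a limit, > 100000 nM. Compound 2 (`O=C(O)C[C@H](NC(=O)c1cncc(S(=O)(=O)NC2CC2)c1)C(=O)Oc1ccccc1`) gives 4300 nM. Compound 3 (`O=C(O)C[C@H](NC(=O)c1cncc(S(=O)(=O)NCc2ccccc2)c1)C(=O)CSCc1ccc(F)cc1`) gives 59000 nM, the higher of the two actual numbers, and its nearest neighbour, compound 2, lies lower by more than the scatter.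

Next is compound 4 (`CCN(CC)S(=O)(=O)c1cncc(C(=O)N[C@@H](CC(=O)O)C(=O)CSCc2ccc(F)cc2)c1`), with diethylamino in place of benzylamino on a sulfonyl sulfur.

Within the data shown here, only one measured step bears on this change: an at least 1.6-fold lower number from compound 1 to compound 3 (0.22 log units; that floor lies within the scatter), with benzylsulfamoyl in place of dipropylcarbamoyl on an aromatic carbon. It is bounded only by a floor, and that floor lies within the scatter, so it gives neither a size nor a direction for the new change. Also relevant is the limit of > 100000 nM in this assay, at which 1 of the 3 values shown sits.

No step beyond the scatter is therefore expected in this assay. For compound 4 the expected value is 60000 nM. The estimated range for compound 4 runs from 20000 nM to 150000 nM. The expected change is a 1.0-fold higher number from compound 3 to compound 4 (0.01 log units; within the scatter).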

Compound 4, half-maximal inhibitory concentration: 12000 nM
Compound 4: middle estimate off by 5.0-fold (0.70 log units), on the high side, and the stated range ends above it.
By their numbers in this assay, from the lowest: compound 2; then compound 4; then compound 3. At a limit, above all of these: compound 1.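

Among these compounds, exchanging benzylamino for diethylamino on the sulfonyl sulfur gives a 4.9-fold lower number from compound 3 to compound 4 (0.69 log units; beyond the scatter) in this assay, so the group on this sulfur can move the read-out beyond the scatter, which the earlier compounds did not show. The exchange of dipropylcarbamoyl for diethylsulfamoyl gives an at least 8.3-fold lower number from compound 1 to compound 4 (0.92 log units; beyond the scatter) and its floor now clears the scatter, so the direction of this change can be read, though not its full size. That step stays a floor because compound 1 stands only at a limit: the limit of > 100000 nM in this assay, at which 1 of the 4 values shown sits.

The change from benzylamino to diethylamino removes the ring and the hydrogen-bond donor together, and the compounds shown do not separate the two. From the compounds shown here alone, how piperidine or morpholine on the same sulfur would read remains open.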